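The compounds below may be only part of what the source reports. "The series", "measured", "known", "first", "only" and "open" are said of these compounds alone.

For the measured compounds named here, in a functional assay on HeLa cells (Homo sapiens) for antiproliferative activity, read by MTT assay, with a stated time of 72 h (a higher number here means a weaker inhibitor, a lower number a stronger inhibitor), compound 2 `COc1ccc2occ(CSC(=S)N3CCCCC3)c(=O)c2c1` gives 3500 nM, the lowest of the three numbers measured so far, though both gaps to the other compounds lie within the scatter. Compound 1 `O=c1c(Cl)c(CSC(=S)N2CCOCC2)oc2ccccc12` gives 4500 nM, and compound 3 `Cc1ccc2c(=O)c(CSC(=S)N3CCOCC3)coc2c1` gives 6100 nM. On these numbers the three compounds stand level. Compound 4 `COc1ccc2occ(CSC(=S)N3CCOCC3)c(=O)c2c1` has not yet been measured; it differs from compound 2 in one place: morpholin-4-yl in place of piperidin-1-yl on a thiocarbonyl carbon. Going by the values given here, no measured pair shows this change on its own, so there is no direct step to lean on. The expected step is a 1.3-fold higher number from compound 2 to compound 4 (0.11 log units; within the scatter), no larger than the scatter in either direction. The estimate for compound 4 is therefore 4500 nM, with a range from 2000 nM to 10000 nM.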

Compound 4, half-maximal inhibitory concentration: 9500 nM
Beside the measured number, compound 4's estimate is 2.1-fold (0.32 log units) below it; low and high end bracket the measured number.
By their numbers in this assay, from the lowest: compounds 2, 1, 3 and 4 (each within the scatter of the next, the first and the last beyond it).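

In this assay, for the compounds shown here, morpholin-4-yl in place of piperidin-1-yl on a thiocarbonyl carbon gives a 2.7-fold higher number from compound 2 to compound 4 (0.43 log units; beyond the scatter) and this modest step lies beyond the scatter, which no earlier pair could show. The group at this position can therefore shift the number, at least on the core of compound 2. No measurement shown gives a reason for the step.

As far as these compounds go, whether the same change acts alike on other cores remains open. So does the effect of a pyrrolidin-1-yl or dimethylamino group at this position.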